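The compounds below may be only part of what the source reports. "The series", "measured", "known", "first", "only" and "open" are said of these compounds alone.

Among the measured compounds shown here, compound 3 `CCCCCCCCCCCCCC/N=c1\nc(N)c2ncn(Cc3ccccc3)c2c(N)n1` gives the lowest number so far in a functional assay on A549 cells (Homo sapiens) for antiproliferative activity, read by WST assay, with a stated time of 72 h; on this read-out lower numbers stand for stronger inhibition and higher numbers for weaker inhibition: compound 3 gives 4250 nM. Its nearest neighbour is compound 2 `CCCCCCCCCCCCCCCCCC/N=c1\nc(N)c2ncn(Cc3ccccc3)c2c(N)n1`, which in this assay gives 5300 nM; compound 1 `Nc1n/c(=N\CCCCc2ccccc2)nc(N)c2c1ncn2Cc1ccccc1` in this assay gives 15300 nM. The step of a 3.6-fold lower number from compound 1 to compound 3 (0.56 log units; beyond the scatter) is the only one that moves beyond the scatter; the step of a 1.2-fold lower number from compound 2 to compound 3 (0.10 log units; within the scatter) does not.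

Compound 4 `CCCCCCCCCC/N=c1\nc(N)c2ncn(Cc3ccccc3)c2c(N)n1` differs from compound 3 by hydrogen in place of butyl on a saturated chain carbon, ten or more bonds along the chain from a double-bonded nitrogen. This is the same kind of change as the step from compound 2 to compound 3, applied once more to the chain end. That earlier step, a 1.2-fold lower number from compound 2 to compound 3 (0.10 log units; within the scatter), stayed within the scatter, so shortening the chain further by four carbons is expected to leave this assay essentially unchanged, with a small drift toward weaker inhibition allowed by the weaker number of compound 1 at 15300 nM. The expected step is a 1.3-fold higher number from compound 3 to compound 4 (0.11 log units; within the scatter). Compound 4 is therefore estimated at 5500 nM, with a range from 2500 nM to 12000 nM.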

Compound 4, half-maximal inhibitory concentration: 1800 nM
Beside the measured number, compound 4's estimate is 3.1-fold (0.49 log units) above it; the measured number lies below the stated range.
By their numbers in this assay, from the lowest: compound 4; then compounds 3 and 2 (each within the scatter of the next); then compound 1.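

In this assay, the same change, hydrogen in place of butyl on a saturated chain carbon, ten or more bonds along the chain from a double-bonded nitrogen, now gives a 2.4-fold lower number from compound 3 to compound 4 (0.37 log units; beyond the scatter), whereas the earlier 1.2-fold lower number from compound 2 to compound 3 (0.10 log units; within the scatter) did not leave the scatter. The effect of this change therefore depends on the chain length it starts from, and the wider comparison, hydrogen in place of octyl, gives a 2.9-fold lower number from compound 2 to compound 4 (0.47 log units; beyond the scatter). Against the phenyl-ended chain, hexyl in place of phenyl gives an 8.5-fold lower number from compound 1 to compound 4 (0.93 log units; beyond the scatter), leaving compound 4 with the lowest number of the four.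

No measurement shown here bears on the reason for this shift. Open, as far as these compounds go, is whether a shorter chain, such as hexyl, lowers the number further, and how an amine or a carboxylic acid on the chain would read.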